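Fluoro in Place of Hydrogen on Two Related Cores

The source may hold more compounds than are shown below. What is called first, only, known or untested is meant among the compounds shown, and "the series" means these compounds.

Compound 1 `COc1cccc(Nc2nc(C)cc(N(C)C)n2)c1`: in an ADME assay on Vero cells (Chlorocebus sabaeus) for cytotoxicity (a higher number here means that more compound is needed for the effect, a lower number that less compound is needed), compound 1 gives > 50100 nM, a limit of the assay.
Compound 2 `COc1cc(Nc2nc(C)cc(N(C)C)n2)ccc1F`: in this assay compound 2 gives 31600 nM.
Compound 3 `COc1cccc(Nc2cc(C)nc(NCc3ccccc3)n2)c1`: in this assay compound 3 gives 7940 nM.

The value of compound 1 is a limit, not a number (the limit of > 50100 nM in this assay, at which 1 of the 3 values shown sits). The change from compound 1 to compound 2, (fluoro in place of hydrogen on an aromatic carbon), gave an at least 1.5-fold lower number from compound 1 to compound 2 (0.20 log units; that floor lies within the scatter). Compound 3 stands lowest of the two numbers; the difference between its core and the core of compound 1 is not broken down here.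

Compound 4 `COc1cc(Nc2cc(C)nc(NCc3ccccc3)n2)ccc1F` carries the same change on the core of compound 3: fluoro in place of hydrogen on an aromatic carbon. Its step is expected to be a 1.3-fold lower number from compound 3 to compound 4 (0.10 log units; within the scatter), resting on the step of an at least 1.5-fold lower number from compound 1 to compound 2 (0.20 log units; that floor lies within the scatter). Compound 4 is therefore estimated at 6300 nM.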

Compound 4, half-maximal effective concentration in the Vero assay: 5010 nM
Estimate against measurement, compound 4: 1.3-fold (0.10 log units) above; low and high end bracket the measured number.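

In the Vero assay, fluoro in place of hydrogen on the core of compound 3 gave a 1.6-fold lower number from compound 3 to compound 4 (0.20 log units; within the scatter). In the Vero assay compound 1 gives > 50100 nM, which is a limit of the assay. The new step can be set beside the same change on the core of compound 1: the same change on two cores in the Vero assay, an at least 1.5-fold lower number (0.20 log units; that floor lies within the scatter) from compound 1 to compound 2 and a 1.6-fold lower number (0.20 log units; within the scatter) from compound 3 to compound 4; the limit leaves it open whether they differ. The new step lies within the scatter and the earlier one is known only as a floor, so the pair does not show that the change carries across the two cores with a fixed size.

In a physicochemical assay for solubility, read by nephelometry, measured as kinetic solubility (a higher number here means a more soluble compound, a lower number a less soluble compound), compound 3 gives > 250000 nM, which is a limit of the assay. In the physicochemical assay compound 4 gives 180000 nM. The compounds shown leave open whether chloro or a nitrile in place of the fluoro would give a step beyond the scatter in the Vero assay. They also leave open whether the step in the physicochemical assay, an at least 1.3-fold lower number from compound 3 to compound 4 (0.14 log units; that floor lies within the scatter), would recur on the core of compound 1.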